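The source may report more compounds than this note shows. Statements on the series, on what has been measured and on what is new or still open speak of the compounds shown alone.

Series notes. Compound 1 `CCS(=O)(=O)Nc1ccc(NC(=O)c2cccc(C(F)(F)F)c2)cc1Cl` and compound 2 `O=C(Nc1ccc(NS(=O)(=O)C(F)(F)F)c(Cl)c1)c1cccc(C(F)(F)F)c1` are built on one core; compound 3 `CCS(=O)(=O)Nc1ccc(NC(=O)c2ccc(Cl)cc2)cc1F` and compound 4 `O=C(Nc1ccc(NS(=O)(=O)C(F)(F)F)c(F)c1)c1ccc(Cl)cc1` are built on a second. The difference between the two cores is not broken down here. In an ADME assay on HEK293 cells (Homo sapiens) for cytotoxicity, read by MTT assay, with a stated time of 48 h (on this read-out higher numbers stand for weaker inhibition and lower numbers for stronger inhibition), compound 1 gives 159000 nM. Compound 2 gives 210000 nM in this assay. The change between these two is trifluoromethyl in place of ethyl on a sulfonyl sulfur, and it made a 1.3-fold higher number from compound 1 to compound 2 (0.12 log units; within the scatter). Compound 3 gives 53400 nM in this assay; this is the lowest of the three measured numbers, and its gaps to compound 1 and to compound 2 both lie beyond the scatter. Compound 4 has not yet been measured in this assay. Its difference from compound 3 is trifluoromethyl in place of ethyl on a sulfonyl sulfur; the place is the same, word for word, as in the pair from compound 1 to compound 2, so this is the same change carried onto the second core. Going by the values given here, only one measured instance of this change exists among the four compounds, which limits what can be said of it. For compound 4 in this assay a step about as small as the earlier one is expected, a 1.2-fold higher number from compound 3 to compound 4 (0.09 log units; within the scatter). This rests on compound 3 at 53400 nM and on the earlier step of a 1.3-fold higher number from compound 1 to compound 2 (0.12 log units; within the scatter). The estimate for compound 4 is 65000 nM, with a range from 30000 nM to 150000 nM.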

Compound 4, half-maximal inhibitory concentration: 79000 nM
For compound 4 the middle estimate is 1.2-fold (0.08 log units) below the measured one; the range from low to high includes it.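

In this assay, trifluoromethyl in place of ethyl on a sulfonyl sulfur on the second core gives a 1.5-fold higher number from compound 3 to compound 4 (0.17 log units; within the scatter), so the step is again small enough to stay within the scatter. Set side by side, the two instances of this change cannot be told apart: the same change on two cores in this assay, a 1.3-fold higher number (0.12 log units; within the scatter) from compound 1 to compound 2 and a 1.5-fold higher number (0.17 log units; within the scatter) from compound 3 to compound 4, 1.1-fold (0.05 log units) apart, within the scatter of two such steps. This shows that the change carries between these two cores without a readable difference in this read-out, but it does not show that either step is a real effect, since neither separates its two compounds, and two pairs say nothing about a core other than these two or about any other read-out.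

Still open, as far as these compounds go, is whether the step stays this small when a longer chain such as propyl, a phenyl ring or an amine stands on the sulfonyl sulfur in place of ethyl or trifluoromethyl. Also open is what the difference between the two cores contributes, as no pair shown isolates it.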